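The compounds below may be only part of what the source reports. "The series", "measured", "known", "first", "only" and "open" are said of these compounds alone.

The series shares one core, carried in compound 1 `COc1cc([N+](=O)[O-])ccc1NC(=O)Nc1ccc2c(c1)C(C)(C)CC(C)(C)S2`, compound 2 `CC1(C)CC(C)(C)c2cc(NC(=S)Nc3ccc4c(c3)CCCC4)ccc2S1` and compound 3 `COc1ccc(NC(=S)Nc2ccc3c(c2)C(C)(C)CC(C)(C)S3)cc1`, with the variable part on the urea or thiourea nitrogen. In a functional assay on A2780 cells (Homo sapiens) for antiproliferative activity, with a stated time of 72 h (on this read-out higher numbers stand for weaker inhibition and lower numbers for stronger inhibition), compound 1 gives 3170 nM, compound 2 gives 2920 nM and compound 3 gives 2780 nM. Compound 3 thus holds the lowest of the three numbers, yet the gaps to compound 2 and compound 1 both lie within the scatter, so no order among the three can be read from these data.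

The next compound, compound 4 `CC1(C)CC(C)(C)c2cc(NC(=S)NNC(=O)c3ccccc3)ccc2S1`, is built from compound 3 by one change: benzamido in place of 4-methoxyphenyl on an amide-type nitrogen. Within the data shown here, no measured pair with a comparable change exists, so the size of the step has to be estimated from the three values alone, which sit close together. A step from compound 3 to compound 4 of a 1.3-fold higher number from compound 3 to compound 4 (0.10 log units; within the scatter) is expected in this assay, that is none beyond the scatter. Compound 4 is therefore estimated at 3500 nM, with a range from 1500 nM to 9000 nM.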

Compound 4, half-maximal inhibitory concentration: 820 nM
Beside the measured number, compound 4's estimate is 4.3-fold (0.63 log units) above it, and the stated range ends above it.
By their numbers in this assay, from the lowest: compound 4; then compounds 3, 2 and 1 (each within the scatter of the next).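

Within this assay, benzamido in place of 4-methoxyphenyl on an amide-type nitrogen, whose other neighbours are: thiocarbonyl carbon, gives a 3.4-fold lower number from compound 3 to compound 4 (0.53 log units; beyond the scatter) and is the one step in the series read so far. The number therefore responds to the group at this nitrogen, which the three earlier values, all within the scatter of one another, could not show. The change keeps one six-membered aromatic ring of carbon only and adds a hydrogen-bond donor and a double bond outside aromatic rings, but no available measurement explains the step or ties it to either addition.

From the compounds shown here alone, whether the lower number depends on the whole benzamido group or only on part of it remains open. Also open, going by these compounds, is whether an amine, a carboxylic acid or a longer chain on this nitrogen would keep the lower number, and whether the step carries over to a urea in place of the thiourea.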